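Removing the chloro: compound 2 to compound 3

A few compounds are considered here, and "the series" means these few. Any claim that something is new, unique, unknown or untested is made for them only; others in the source may bear on it.

Compounds measured so far:
compound 1 `CC(C)C1(C(C)C)NC(=O)N(CN2CCN(c3cccc(C(F)(F)F)c3)CC2)C1=O` — 100 mg/kg
compound 2 `O=C1NC(c2ccccc2)(c2ccccc2)C(=O)N1CN1CCN(c2cccc(Cl)c2)CC1` — 100 mg/kg

Of the compounds shown here, two have been tested in a functional assay on the whole organism (strain CD1) with Mus musculus as the target, in the maximal electroshock model, with a stated time of 4 h; a lower number here means that less compound is needed, a higher number that more compound is needed for the effect. Compound 1 `CC(C)C1(C(C)C)NC(=O)N(CN2CCN(c3cccc(C(F)(F)F)c3)CC2)C1=O` gives 100 mg/kg in this assay. Compound 2 `O=C1NC(c2ccccc2)(c2ccccc2)C(=O)N1CN1CCN(c2cccc(Cl)c2)CC1` gives 100 mg/kg in this assay, which is level with compound 1 at the digits shown, the two values lying within the scatter of each other. Going by the values given here, no step between compounds differing in a single place has been measured, so the two values say only that both compounds reach the same dose.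

The next compound is compound 3 `O=C1NC(c2ccccc2)(c2ccccc2)C(=O)N1CN1CCN(c2ccccc2)CC1`, which differs from compound 2 by a single change: hydrogen in place of chloro on an aromatic carbon. The rest of the shared core stays as it is.

Among the compounds with values here, with no measured single-point step to lean on, and with compound 1 and compound 2 sitting at the same value, the expectation for the step of no change at the digits printed from compound 2 to compound 3 (within the scatter) is that it stays within the scatter, with no clear direction. Compound 3 is therefore estimated at 100 mg/kg in this assay, with a range from 50 mg/kg to 300 mg/kg.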

Compound 3, minimum effective dose: 100 mg/kg
Beside the measured number, compound 3's estimate shows no gap at the digits printed; low and high end bracket the measured number.
By their numbers in this assay, from the lowest: compounds 1, 2 and 3 (each within the scatter of the next).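

In this assay, going by these compounds alone, the exchange of 3-chlorophenyl to phenyl gives no change at the digits printed from compound 2 to compound 3 (within the scatter), and this is the first step that isolates a single place. It shows that on this core the chloro on an aromatic carbon, meta to a large group, can give way to hydrogen with the minimum effective dose staying within the scatter, so the chlorine atom is not required for the dose reached here. Nothing measured in this series bears on why the dose holds across this change.

On these data alone, it remains open whether another group on this aromatic carbon, such as methoxy, an amine or a carboxylic acid, would shift the dose on this core, as a single exchange of chloro for hydrogen speaks only for those two substituents. As far as these compounds go, it is also open whether the same exchange would read alike on the core of compound 1, which differs from compound 3 in more than one place and so cannot be set against it here.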